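Chloro for Fluoro: Solubility Across Two Cores

The source may report more compounds than this note shows. Statements on the series, on what has been measured and on what is new or still open speak of the compounds shown alone.

Measured compounds in a physicochemical assay for solubility, read by HPLC, in phosphate buffer, measured as kinetic solubility, at pH 7.4; on this read-out higher numbers stand for higher solubility and lower numbers for lower solubility:
compound 1 `CCOC(=O)c1cc(-c2ccc(Cl)cc2)n(-c2ccc(S(N)(=O)=O)cc2)c1N` gives 4400 nM
compound 2 `CCOC(=O)c1cc(-c2ccc(F)cc2)n(-c2ccc(S(N)(=O)=O)cc2)c1N` gives 7500 nM
compound 3 `CCOC(=O)c1cc(-c2ccc(F)cc2)n(-c2ccc(S(N)(=O)=O)cc2)n1` gives 56400 nM

Compound 1 and compound 2 share one core; compound 3 carries another. The difference between the two cores is not broken down here, but in this assay compound 3 stands highest of the three, its nearest neighbour being compound 2, and both gaps lie beyond the scatter.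

Within the first pair the change is chloro in place of fluoro on an aromatic carbon, and the step it made is a 1.7-fold lower number from compound 2 to compound 1 (0.23 log units; within the scatter), within the scatter. Compound 4 `CCOC(=O)c1cc(-c2ccc(Cl)cc2)n(-c2ccc(S(N)(=O)=O)cc2)n1`, not yet measured, carries the same change on the core of compound 3: chloro in place of fluoro on an aromatic carbon. The place lines of the two changes agree word for word, so this is the same change.

From that single precedent, compound 4 is expected to give a 1.7-fold lower number from compound 3 to compound 4 (0.23 log units; within the scatter) in this assay, a step resting on a 1.7-fold lower number from compound 2 to compound 1 (0.23 log units; within the scatter) and on the value of compound 3, 56400 nM. Compound 4 is thus estimated at 33000 nM, between 15000 nM and 70000 nM. Two occurrences of the change are too few to claim a pattern.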

Compound 4, solubility: 53300 nM
Compound 4: the middle estimate sits 1.6-fold (0.21 log units) below what was measured, within the range that was stated.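

In this assay chloro in place of fluoro on an aromatic carbon was carried to a second core, where the step reads (a 1.1-fold lower number from compound 3 to compound 4 (0.02 log units; within the scatter)), and the step on the first core reads (a 1.7-fold lower number from compound 2 to compound 1 (0.23 log units; within the scatter)). For the compounds shown here, both steps lie within the scatter, so in these two pairs the change from 4-fluorophenyl to 4-chlorophenyl gave no step that stands clear of repeat measurement on either core, but two pairs do not show that the same would hold on any further core. Nothing measured here bears on why the change behaved this way on either core.

The compounds shown leave open whether a different group in the same place, such as a nitrile, a methoxy group or an amine, would also stay within the scatter on both cores. They also leave open how a carboxylic acid in place of the ethyl ester would read on either core.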